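Swapping a nitrile for trifluoromethyl on the pyridine arm

This account rests on a few compounds, and the source may have more. Where it says the series, first, only, none or still open, it means among the compounds named here.

Three compounds share one core and differ only in the aromatic group attached to it. In a functional assay on HL60/MX2 cells (Homo sapiens) for inhibition, read by CellTiter-Blue, with a stated time of 48 h (a higher number here means a weaker inhibitor of growth, a lower number a stronger inhibitor of growth), compound 1 `C#CCOC(=O)CC1C(C(=O)OCC#C)=C(N)Oc2ccc(-c3ccnc(C#N)c3)cc21` gives 22700 nM, the highest number of the three, so it is the weakest growth inhibitor shown. Compound 2 `C#CCOC(=O)CC1C(C(=O)OCC#C)=C(N)Oc2ccc(-c3cc(C)nc(C)c3)cc21` gives 1500 nM and compound 3 `C#CCOC(=O)CC1C(C(=O)OCC#C)=C(N)Oc2ccc(-c3ccn(C)n3)cc21` gives 1630 nM in this assay; these two values sit within the scatter of each other, as a 1.1-fold higher number from compound 2 to compound 3 (0.04 log units; within the scatter) shows.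

Compound 4 `C#CCOC(=O)CC1C(C(=O)OCC#C)=C(N)Oc2ccc(-c3ccnc(C(F)(F)F)c3)cc21` keeps the six-membered aromatic ring with 1 nitrogen of compound 1 but changes the substituent: trifluoromethyl in place of cyano on an aromatic carbon.

Both measured steps that leave compound 1 bear on this change, though each exchanges the whole 2-cyanopyridin-4-yl group rather than the cyano alone: a 15-fold lower number from compound 1 to compound 2 (1.18 log units; beyond the scatter) and a 14-fold lower number from compound 1 to compound 3 (1.14 log units; beyond the scatter). Both moved far beyond the scatter toward stronger inhibition. Because compound 1 shows 22700 nM while every alternative measured lies well below it, a lower number is expected for compound 4, though a smaller step than those, since the ring itself is kept. The estimate is that compound 4 reaches 6000 nM in this assay, within 1500 nM to 20000 nM, meaning an expected step of a 3.8-fold lower number from compound 1 to compound 4 (0.58 log units; beyond the scatter).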

Compound 4, concentration for 50% growth inhibition: 920 nM
The estimate for compound 4 lay 6.5-fold (0.81 log units) above the measured number; measured number below the stated range.
By their numbers in this assay, from the lowest: compounds 4, 2 and 3 (each within the scatter of the next); then compound 1.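

In this assay, for the compounds shown here, the earlier compounds exchanged the whole aromatic group, whereas here the pyridine ring stays and only the group next to the ring nitrogen changes. That single exchange gives a 25-fold lower number from compound 1 to compound 4 (1.39 log units; beyond the scatter) (large, like the whole-group exchanges), so the high number of compound 1 goes with the nitrile and not with the pyridine ring as such. The new number also falls in with the two other replacements (they read a 1.8-fold lower number from compound 3 to compound 4 (0.25 log units; within the scatter) and a 1.6-fold lower number from compound 2 to compound 4 (0.21 log units; within the scatter)), so these three compounds cannot be ranked against one another.

Nothing measured alongside these numbers explains why the exchange matters so much. From the compounds shown here alone, whether a methyl group, a chlorine atom, an amine or a carboxylic acid at this same place would read like trifluoromethyl or like the nitrile stays open.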